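The compounds below may be only part of what the source reports. "The series", "measured", "known", "first", "only" and "open" are said of these compounds alone.

Compound 1 `Cc1ccnc(/C(N)=N/NC(=S)N2CCSCC2)c1`: 3.89%
Compound 2 `Cc1ccnc(/C(N)=N/NC(=S)N2CCCC2)c1`: 49%
Compound 3 `N/C(=N\NC(=S)N1CCSCC1)c1ccccn1`: 16.3%

These three compounds were tested in a functional assay on MCF7 cells (Homo sapiens) for cytotoxicity, read by MTT assay, with a stated time of 72 h, tested at 1 uM; on this read-out lower numbers stand for less inhibition of growth and higher numbers for more inhibition of growth at the one concentration tested. Compound 3 stands second highest of the three numbers. Its nearest neighbour is compound 1, and the step of a number 12.4 percentage points higher from compound 1 to compound 3 (beyond the scatter) separates them, the change being hydrogen in place of methyl on an aromatic carbon. Its furthest neighbour is compound 2, which gives 49%, whereas compound 3 gives 16.3%.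

Compound 4 `N/C(=N\NC(=S)N1CCCCC1)c1ccccn1` has not yet been measured. It differs from compound 3 in one place: piperidin-1-yl in place of thiomorpholin-4-yl on a thiocarbonyl carbon.

Within the data shown here, one measured step bears on this change. The step of a number 45.1 percentage points higher from compound 1 to compound 2 (beyond the scatter) replaced the same thiomorpholin-4-yl on a thiocarbonyl carbon with pyrrolidin-1-yl, a different but related ring, and it was large. Piperidin-1-yl is not pyrrolidin-1-yl, so that step is a guide rather than a match. On that guide, an upward step beyond the scatter in this assay is expected for compound 4, though its size is uncertain. Compound 4 is estimated to give 45%, with a range from 15% to 75%, meaning an expected step of a number 28.7 percentage points higher from compound 3 to compound 4 (beyond the scatter).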

Compound 4, percent growth inhibition at one concentration: 15.4%
Beside the measured number, compound 4's estimate is 29.6 percentage points above it, and the stated range covers the measured number.
By their numbers in this assay, from the lowest: compound 1; then compounds 4 and 3 (each within the scatter of the next); then compound 2.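

In this assay, piperidin-1-yl in place of thiomorpholin-4-yl on a thiocarbonyl carbon gives a number 0.9 percentage points lower from compound 3 to compound 4 (within the scatter) and so leaves the read-out where it was on the core of compound 3. Replacing thiomorpholin-4-yl at this place therefore does not raise the number in every case, and the step of a number 45.1 percentage points higher from compound 1 to compound 2 (beyond the scatter) cannot be taken as a general result of removing that ring, as it differs in both the entering ring and the core that carries it.

The compounds shown leave open whether that large step belongs to pyrrolidin-1-yl itself or depends on the methyl on the aromatic carbon. They also leave open how a morpholin-4-yl ring or a dimethylamino group would read on the same thiocarbonyl carbon. No measurement offered here explains why the two ring changes read so differently.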